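A few compounds are considered here, and "the series" means these few. Any claim that something is new, unique, unknown or untested is made for them only; others in the source may bear on it.

In a functional assay on KYSE-410 cells (Homo sapiens) for antiproliferative activity, read by MTT assay, with a stated time of 72 h (on this read-out lower numbers stand for stronger inhibition and higher numbers for weaker inhibition), three compounds sharing one core have been measured, and they differ only in the ring attached to an aromatic carbon of that core. Compound 1 `CC(C)(C)c1ccc(-c2ccc3c(C(=O)Nc4cccc(F)c4)cc(=O)[nH]c3c2)cc1` gives only a limit, > 20000 nM. Compound 2 `COc1ccc(-c2ccc3c(C(=O)Nc4cccc(F)c4)cc(=O)[nH]c3c2)cc1` gives 18000 nM and compound 3 `O=C(Nc1cccc(F)c1)c1cc(=O)[nH]c2cc(-c3cccc(F)c3)ccc12` gives 10900 nM, two numbers within the usual scatter of each other.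

Compound 4 `O=C(Nc1cccc(F)c1)c1cc(=O)[nH]c2cc(-c3ccc(F)nc3)ccc12` changes that ring once more: 6-fluoropyridin-3-yl in place of 3-fluorophenyl on an aromatic carbon. In words, this is 6-fluoropyridin-3-yl in place of 3-fluorophenyl on an aromatic carbon.

The three measured swaps at this same place bear on the question: a 1.7-fold lower number from compound 2 to compound 3 (0.22 log units; within the scatter), an at least 1.8-fold lower number from compound 1 to compound 3 (0.26 log units; that floor lies within the scatter) and an at least 1.1-fold lower number from compound 1 to compound 2 (0.04 log units; that floor lies within the scatter). All of them stay within the scatter. However, each of those rings is of carbon only, so no measured compound shows directly what a ring with a hetero atom does here.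

No step beyond the scatter is therefore expected, and the estimated step is a 1.1-fold lower number from compound 3 to compound 4 (0.04 log units; within the scatter). The estimated value for compound 4 is 10000 nM, with an expected range from 4000 nM to 20000 nM.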

Compound 4, half-maximal inhibitory concentration: > 20000 nM
Compound 4 was reported as a limit (the forecaster's own chance of this, stated with the estimate: 15%); at least 2.0-fold (0.30 log units) between middle value and limit.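

Compound 4 places the first ring with a hetero atom at this position, and its reading in this assay is a limit, not a number: the limit of > 20000 nM in this assay, at which 2 of the 4 values shown sit.
The two readable steps (an at least 1.8-fold higher number from compound 3 to compound 4 (0.26 log units; that floor lies within the scatter)) and (an at least 1.1-fold higher number from compound 2 to compound 4 (0.04 log units; that floor lies within the scatter)) have floors that lie within the scatter, so a real loss against the carbon-only rings is not established, yet the ring nitrogen of 6-fluoropyridin-3-yl shows no gain either. Compound 1 and compound 4 both give limits, so the step between them cannot be read.

The compounds shown leave open what a pyridine ring without the fluorine would do at this position. They also leave open whether a phenyl ring carrying an amine or a carboxylic acid would give a measurable number well clear of the limit.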